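A pyridine swap among three compounds held at a limit

The source may report more compounds than this note shows. Statements on the series, on what has been measured and on what is new or still open speak of the compounds shown alone.

Three compounds with a shared core were tested in a functional assay on HT-29 cells (Homo sapiens) for antiproliferative activity, read by MTT assay, with a stated time of 24 h; a higher number here means a weaker inhibitor, a lower number a stronger inhibitor. Compound 1 `COc1ccc(/C=C/C(=O)c2ccc(OC)c3c2OC(C)(C)C=C3)c(F)c1` gives > 10000 nM, a limit of the assay and not a number. Compound 2 `COc1ccc(C(=O)/C=C/c2ccc(Br)cc2)c2c1C=CC(C)(C)O2` gives > 10000 nM, which is also a limit. Compound 3 `COc1ccc(/C=C/C(=O)c2ccc(OC)c3c2OC(C)(C)C=C3)cn1` gives > 10000 nM, again a limit. Compound 3 therefore stands with the other two, at the limit of > 10000 nM in this assay, at which 3 of the 3 values shown sit.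

Compound 4 `COc1ccc(C(=O)/C=C/c2ccccn2)c2c1C=CC(C)(C)O2` has not yet been measured, and it differs from compound 3 as follows: pyridin-2-yl in place of 6-methoxypyridin-3-yl on a double-bonded chain carbon bound to a double-bonded chain carbon. Pyridin-2-yl thus takes the place of 6-methoxypyridin-3-yl on a double-bonded chain carbon bound to a double-bonded chain carbon.

Three measured exchanges at this same place bear on the change: a step that the two limits leave unreadable from compound 1 to compound 3, a step that the two limits leave unreadable from compound 1 to compound 2 and a step that the two limits leave unreadable from compound 2 to compound 3. None of them has a size that can be read, so they offer no measured effect to carry over. Compound 3 gives only the limit > 10000 nM, so no step beyond the scatter is expected in this assay, and no direction can be named. The expected step is a step that the limit leaves unreadable from compound 3 to compound 4. Compound 4 is estimated at 15000 nM, with an expected range of 4000 nM to 50000 nM, and the assay will probably report only a limit.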

Compound 4, half-maximal inhibitory concentration: 2120 nM
Compound 4: the middle estimate sits 7.1-fold (0.85 log units) above what was measured; the whole stated range lies above it.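

In this assay, the place on a double-bonded chain carbon bound to a double-bonded chain carbon now has an effect that can be read, which the steps among the first three compounds did not allow. Pyridin-2-yl gives an at least 4.7-fold lower number from compound 3 to compound 4 (0.67 log units; beyond the scatter), and it gives an at least 4.7-fold lower number from compound 2 to compound 4 (0.67 log units; beyond the scatter) and an at least 4.7-fold lower number from compound 1 to compound 4 (0.67 log units; beyond the scatter), each beyond the scatter and each stated only as a minimum size. Compound 4 is therefore the only compound shown with a measured number, while the other three remain at one shared limit: the limit of > 10000 nM in this assay, at which 3 of the 4 values shown sit.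

Compound 3 and compound 4 differ both in how the pyridine ring is attached and in the methoxy group, and no compound shown makes one of these changes alone, so the step cannot be assigned to either. On these data alone, whether unsubstituted pyridin-3-yl or pyridin-4-yl would give a measurable number at this place stays open, as does the effect of adding a dimethylamino group to the pyridin-2-yl ring.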